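This account rests on a few compounds, and the source may have more. Where it says the series, first, only, none or still open, it means among the compounds named here.

Measured in a functional assay on MCF7 cells (Homo sapiens) for cytotoxicity, read by MTT assay, with a stated time of 96 h; on this read-out lower numbers stand for stronger inhibition and higher numbers for weaker inhibition:
- compound 1 `COc1cc(C(=O)c2cn(-c3cccc(Cl)c3)cc2-c2ccccc2)cc(OC)c1OC`: 150 nM
- compound 2 `COc1cc(C(=O)c2cn(-c3cccc(Br)c3)cc2-c2ccccc2)cc(OC)c1OC`: 78 nM
- compound 3 `COc1cc(C(=O)c2cn(-c3cccc([N+](=O)[O-])c3)cc2-c2ccccc2)cc(OC)c1OC`: 550 nM

Compound 1 stands within the scatter of one neighbour and clear of the other, with steps of a 1.9-fold lower number from compound 1 to compound 2 (0.28 log units; within the scatter) and a 3.7-fold higher number from compound 1 to compound 3 (0.56 log units; beyond the scatter). Compound 4 `COc1ccc(-n2cc(C(=O)c3cc(OC)c(OC)c(OC)c3)c(-c3ccccc3)c2)cc1` has 4-methoxyphenyl in place of 3-chlorophenyl on an aromatic nitrogen. Within the data shown here, no measured compound carries this group, so the evidence is indirect. The closest guides are the two steps above and a 7.1-fold higher number from compound 2 to compound 3 (0.85 log units; beyond the scatter), all from changes on the same aryl group. A modest rise in this assay is therefore expected, though its direction is uncertain. The expected step is a 1.5-fold higher number from compound 1 to compound 4 (0.17 log units; within the scatter). For compound 4 the estimated value is 220 nM, with an expected range of 60 nM to 800 nM.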

Compound 4, half-maximal inhibitory concentration: 120 nM
Beside the measured number, compound 4's estimate is 1.8-fold (0.26 log units) above it; measured number inside the range.
By their numbers in this assay, from the lowest: compounds 2, 4 and 1 (each within the scatter of the next); then compound 3.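

In this assay, 4-methoxyphenyl on the aromatic nitrogen is level with both halogen-bearing aryl groups, with a 1.3-fold lower number from compound 1 to compound 4 (0.10 log units; within the scatter) and a 1.5-fold higher number from compound 2 to compound 4 (0.19 log units; within the scatter). Among these compounds only 3-nitrophenyl stands apart, with a 4.6-fold lower number from compound 3 to compound 4 (0.66 log units; beyond the scatter). Nothing available explains this difference.

The change to 4-methoxyphenyl alters both the group on the aryl ring and its place, and the compounds shown do not separate the two. As far as these compounds go, how 3-methoxyphenyl, 4-chlorophenyl or an aryl group bearing an amine or a carboxylic acid would behave here remains open.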